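Shortening the Hydroxamate Chain of Compound 2

A few compounds are considered here, and "the series" means these few. Any claim that something is new, unique, unknown or untested is made for them only; others in the source may bear on it.

Measured so far in a functional assay on HepG2 cells (Homo sapiens) for inhibition, read by MTT assay, with a stated time of 72 h; on this read-out higher numbers stand for weaker inhibition and lower numbers for stronger inhibition
- Compound 1 (`CNC(=O)CCCCCCCn1nc(-c2cnc3[nH]ccc3c2)c2c(N)ncnc21`) gives 5630 nM
- Compound 2 (`Nc1ncnc2c1c(-c1cnc3[nH]ccc3c1)nn2CCCCCCCCCC(=O)NO`) gives 11700 nM

Compound 2 holds the higher of the two numbers. Among the compounds with values here, the only measured step is modest and beyond the scatter (a 2.1-fold higher number from compound 1 to compound 2 (0.32 log units; beyond the scatter)). Compound 3 (`Nc1ncnc2c1c(-c1cnc3[nH]ccc3c1)nn2CCCCCCC(=O)NO`) has not yet been measured. It differs from compound 2 on a saturated chain carbon, six bonds along the chain from an aromatic nitrogen, where hydroxycarbamoyl stands in place of 3-(hydroxycarbamoyl)propyl (hydroxycarbamoyl in place of 3-(hydroxycarbamoyl)propyl on a saturated chain carbon, six bonds along the chain from an aromatic nitrogen). Within the data shown here, no measured step makes this exact change, so that single step is only a loose guide. It ran towards a higher number as the larger group came in. A modest move to a lower number is therefore expected in this assay (a 2.6-fold lower number from compound 2 to compound 3 (0.41 log units; beyond the scatter)). Compound 3 is estimated at 4500 nM (expected range 1200 nM to 14000 nM).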

Compound 3, half-maximal inhibitory concentration: 10300 nM
For compound 3 the middle estimate is 2.3-fold (0.36 log units) below the measured one, within the range that was stated.
By their numbers in this assay, from the lowest: compounds 1, 3 and 2 (each within the scatter of the next, the first and the last beyond it).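

In this assay, hydroxycarbamoyl in place of 3-(hydroxycarbamoyl)propyl on a saturated chain carbon, six bonds along the chain from an aromatic nitrogen, gives a 1.1-fold lower number from compound 2 to compound 3 (0.06 log units; within the scatter) and so leaves the read-out unchanged within the scatter. The step with a 1.8-fold higher number from compound 1 to compound 3 (0.26 log units; within the scatter) is also within the scatter, so the separation beyond the scatter seen between compound 1 and compound 2 does not recur for compound 3. No supporting information is available to explain these results.

The compounds shown leave open whether a carboxylic acid or an amine at the chain end would read differently from hydroxycarbamoyl. They also leave open whether a much shorter chain, such as one ending in (hydroxycarbamoyl)methyl, would shift the number beyond the scatter.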